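The compounds below may be only part of what the source reports. "The series", "measured", "known", "first", "only" and "open" are said of these compounds alone.

Compound 1 `OC[C@H]1O[C@@H](n2cnc3c(NCc4ccccc4F)ncnc32)[C@H](O)[C@@H]1O` carries a 2-fluorophenyl group; in an ADME assay on NIH3T3 cells (Mus musculus) for cytotoxicity, with a stated time of 72 h (a higher number here means a weaker inhibitor, a lower number a stronger inhibitor), compound 1 gives only the limit > 166000 nM, so it stands at a floor and not at a number. Compound 2 `OC[C@H]1O[C@@H](n2cnc3c(NCc4ccc(F)cc4)ncnc32)[C@H](O)[C@@H]1O` gives 44300 nM in this assay. Among the measured compounds shown here, the single measured step, an at least 3.7-fold lower number from compound 1 to compound 2 (0.57 log units; beyond the scatter), bears on the change to compound 3 `OC[C@H]1O[C@@H](n2cnc3c(NCc4ccc(F)c(Cl)c4)ncnc32)[C@H](O)[C@@H]1O`, which is 3-chloro-4-fluorophenyl in place of 2-fluorophenyl on a saturated chain carbon bound to a nitrogen on an aromatic ring. Because compound 1 sits at the limit of > 166000 nM in this assay, at which 1 of the 2 values shown sits, any real step can only read as a lower number. A step of at least comparable size, an at least 5.5-fold lower number from compound 1 to compound 3 (0.74 log units; beyond the scatter), is therefore expected, and compound 3 is estimated at 30000 nM, within 8000 nM to 166000 nM.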

Compound 3, half-maximal inhibitory concentration: > 166000 nM
Compound 3: a limit, no number; the forecaster's own chance of this, stated with the estimate: 20%; middle value at least 5.5-fold (0.74 log units) from the limit.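

Compound 3 gives only a limit and not a number. In this assay, chloro in place of hydrogen on an aromatic carbon brings an at least 3.7-fold higher number from compound 2 to compound 3 (0.57 log units; beyond the scatter), so compound 2 alone among the three has a measured value, and a fluorophenyl group at this position does not by itself secure one. The step between the other two cannot be read, and both rest at the same limit: the limit of > 166000 nM in this assay, at which 2 of the 3 values shown sit.

Which of those two compounds lies higher remains open. So does whether a methoxy group or an amine in place of the chloro would give a number in this assay.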